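Replacing nitro with methoxy in an antiproliferative series

A few compounds are considered here, and "the series" means these few. Any claim that something is new, unique, unknown or untested is made for them only; others in the source may bear on it.

In a functional assay on HeLa cells (Homo sapiens) for antiproliferative activity, read by sulforhodamine B assay, with a stated time of 48 h (on this read-out higher numbers stand for weaker inhibition and lower numbers for stronger inhibition), compound 3 (`COc1cc(OC)c2sc(-c3ccc(N/C=C\C(=O)c4cc(OC)c(OC)c([N+](=O)[O-])c4)c(C)c3)nc2c1`) gives 11400 nM, within the scatter of compound 2 (`COc1cc(OC)c2sc(-c3ccc(N/C=C\C(=O)c4cc(OC)c(OC)c(OC)c4Br)c(C)c3)nc2c1`) at 14700 nM and of compound 1 (`COc1cc(OC)c2sc(-c3ccc(N/C=C\C(=O)c4ccc(OC)c(O)c4)c(C)c3)nc2c1`) at 16100 nM. Compound 4 (`COc1cc(OC)c2sc(-c3ccc(N/C=C\C(=O)c4cc(OC)c(OC)c(OC)c4)c(C)c3)nc2c1`) carries methoxy in place of nitro on an aromatic carbon, ortho to a methoxy group and meta to a large group: methoxy in place of nitro on an aromatic carbon. For the measured compounds named here, no measured pair differs in one place only, so the data offer no direct guide to this change. Compound 3 at 11400 nM lies within the scatter of the other two measured compounds, so no step beyond the scatter is expected in this assay. The estimated step is a 1.3-fold lower number from compound 3 to compound 4 (0.10 log units; within the scatter). Compound 4 is estimated at 9000 nM, with an expected range of 2500 nM to 25000 nM.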

Compound 4, half-maximal inhibitory concentration: 16400 nM
Estimate against measurement, compound 4: 1.8-fold (0.26 log units) below; the measured number falls inside the stated range.
By their numbers in this assay, from the lowest: compounds 3, 2, 1 and 4 (each within the scatter of the next).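

In this assay, methoxy in place of nitro on this aromatic carbon gives a 1.4-fold higher number from compound 3 to compound 4 (0.16 log units; within the scatter) and so shows no step beyond the scatter at this position. Hydrogen in place of bromo gives a 1.1-fold higher number from compound 2 to compound 4 (0.05 log units; within the scatter) while 3,4,5-trimethoxyphenyl in place of 3-hydroxy-4-methoxyphenyl on the carbonyl carbon gives a 1.0-fold higher number from compound 1 to compound 4 (0.01 log units; within the scatter) and neither change moves the number beyond the scatter. No measurement shown explains these results. On these data alone, whether an amine or a carboxylic acid on this carbon would give a step beyond the scatter remains open.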